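The source may hold more compounds than are shown below. What is called first, only, known or untested is meant among the compounds shown, and "the series" means these compounds.

Measured so far:
Compound 1, `Cc1ccc(-c2cc(C(=O)NNc3ccc4ccccc4n3)n(Cc3ccccc3)n2)cc1`, gives 44.4%.
Compound 2, `Cc1ccc(-c2cc(C(=O)Oc3ccc(C(C)(C)C)cc3)n(Cc3ccccc3)n2)cc1`, gives 50%.

Both values come from a functional assay on the whole organism (strain Swiss albino) for inhibition, with Mus musculus as the target, read by paw edema, with stated times of 30 min and 270 min, at a dose of 100 mg/kg by the subcutaneous route; on this read-out higher numbers stand for more inhibition at the one dose given (going by the name of the read-out) and lower numbers for less inhibition. Compound 1, with its value of 44.4%, and compound 2, with its value of 50%, sit within the usual scatter of each other, so on the numbers shown compound 2 stands level with compound 1 rather than apart from it; the data contain only these two measured compounds and no single-point step between them.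

The step now followed leads from compound 2 to compound 3, `Cc1ccc(-c2cc(C(=O)Oc3ccc(Oc4ccc(C(F)(F)F)cc4)cc3)n(Cc3ccccc3)n2)cc1`. The change is 4-(trifluoromethyl)phenoxy in place of tert-butyl on an aromatic carbon. Within the data shown here, no comparable step is available among the measured compounds, so nothing in the data points to a move in either direction; the expectation is a step of no change at the digits printed from compound 2 to compound 3 (within the scatter), none beyond the scatter. Compound 3 is therefore expected to give about 50% in this assay, within a range from 30% to 70%.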

Compound 3, a percentage reported as inhibition, in the whole organism at one dose (the size of the read-out at that dose, not a potency): 22.2%
For compound 3 the middle estimate is 27.8 percentage points above the measured one, and the stated range ends above it.
By their numbers in this assay, from the lowest: compound 3; then compounds 1 and 2 (each within the scatter of the next).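

In this assay, the position on the six-membered aromatic ring of carbon only turns out to be sensitive to the group it carries: putting 4-(trifluoromethyl)phenoxy in place of tert-butyl gives a number 27.8 percentage points lower from compound 2 to compound 3 (beyond the scatter) in this single pair. This is the only step among the compounds shown, and it lies beyond the scatter, so the position is not indifferent to this exchange; the entering group, with its added aromatic ring and hydrogen-bond acceptor, goes with less inhibition at the one dose given. Nothing available here indicates what lies behind this loss.

The compounds shown leave open whether the loss follows the phenoxy oxygen, the second aromatic ring or the trifluoromethyl group. They also leave open how this position would respond to a methoxy group, an amine or a carboxylic acid.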